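The source may report more compounds than this note shows. Statements on the series, on what has been measured and on what is new or still open speak of the compounds shown alone.

Compound 1 `CC1CCN(Cc2ccc3nc(NC(=O)N/N=C/c4cn(Cc5cccc(Cl)c5)c5ccccc45)sc3c2)CC1`: 280 nM
Compound 2 `CN(C)Cc1ccc2nc(NC(=O)N/N=C/c3cn(Cc4ccccc4)c4ccccc34)sc2c1`: 400 nM

In a functional assay on NCI-H460 cells (Homo sapiens) for cytotoxicity, read by MTT assay, with a stated time of 72 h (on this read-out lower numbers stand for stronger inhibition and higher numbers for weaker inhibition), compound 2 gives 400 nM. Among the measured compounds shown here, this number lies within the usual scatter of the only other measurement, that of compound 1 at 280 nM. Compound 3 `CC1CCN(Cc2ccc3nc(NC(=O)N/N=C/c4cn(Cc5ccccc5)c5ccccc45)sc3c2)CC1` has not yet been measured. It departs from compound 2 by one change, 4-methylpiperidin-1-yl in place of dimethylamino on a saturated chain carbon bound to an aromatic carbon. For the measured compounds named here, no measured pair shows this change on its own, so the expectation rests on little. Compound 1 also carries 4-methylpiperidin-1-yl and gives 280 nM, so no step beyond the scatter is expected in this assay. The expected step is a 1.3-fold lower number from compound 2 to compound 3 (0.12 log units; within the scatter). For compound 3 the estimated value is 300 nM, with an expected range from 130 nM to 700 nM.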

Compound 3, half-maximal inhibitory concentration: 1910 nM
For compound 3 the middle estimate is 6.4-fold (0.80 log units) below the measured one; the whole stated range lies below it.
By their numbers in this assay, from the lowest: compounds 1 and 2 (each within the scatter of the next); then compound 3.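

In this assay the swap of dimethylamino for 4-methylpiperidin-1-yl on a saturated chain carbon bound to an aromatic carbon gives a 4.8-fold higher number from compound 2 to compound 3 (0.68 log units; beyond the scatter) and so shows that the number responds to the amine at this place, which compound 1 and compound 2, differing in two places, could not show. With 4-methylpiperidin-1-yl held fixed, hydrogen in place of chloro on an aromatic carbon gives a 6.8-fold higher number from compound 1 to compound 3 (0.83 log units; beyond the scatter) so the 4-methylpiperidin-1-yl compounds depend on that chloro in this assay. Nothing measured here accounts for either step.

The compounds shown leave open whether dimethylamino would gain anything from the same chloro. They also leave open how a morpholin-4-yl group in place of the amine, or a fluoro or methoxy group in place of the chloro, would read.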